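A Fluorine Added to the Phenyl Arm

This account rests on a few compounds, and the source may have more. Where it says the series, first, only, none or still open, it means among the compounds named here.

Measured so far:
Compound 1 `COC(=O)c1sc2cc(OC)ccc2c1C#Cc1ccccc1` gives 54900 nM in a functional assay on NCI-H460 cells (Homo sapiens) for cytotoxicity, read by sulforhodamine B assay, with a stated time of 48 h; on this read-out higher numbers stand for weaker inhibition of growth and lower numbers for stronger inhibition of growth.
Compound 2 `COC(=O)c1sc2ccccc2c1C#Cc1ccccc1` gives 64700 nM in this assay.

Within the data shown here, compound 2 has the highest of the two numbers, and the one step known, a 1.2-fold higher number from compound 1 to compound 2 (0.07 log units; within the scatter), lies within the scatter. Compound 3 `COC(=O)c1sc2ccccc2c1C#Cc1ccc(F)cc1` differs from compound 2 by fluoro in place of hydrogen on an aromatic carbon. No measured step touches this ring, so nothing shown here bears directly on the change, and no step beyond the scatter is expected. Compound 3 is therefore estimated at 60000 nM, between 25000 nM and 150000 nM, a step of a 1.1-fold lower number from compound 2 to compound 3 (0.03 log units; within the scatter) that is expected to stay within the scatter.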

Compound 3, concentration for 50% growth inhibition: 76100 nM
Beside the measured number, compound 3's estimate is 1.3-fold (0.10 log units) below it; measured number inside the range.
By their numbers in this assay, from the lowest: compounds 1, 2 and 3 (each within the scatter of the next).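

In this assay, the phenyl arm now has its own measured change: going from phenyl to 4-fluorophenyl gives a 1.2-fold higher number from compound 2 to compound 3 (0.07 log units; within the scatter). A fluoro at this place, para to a large group, therefore leaves the number within the scatter, as the earlier change on the other aromatic position also did. No measured information is available to explain this result.

From the compounds shown here alone, it remains open whether an amine or a carboxylic acid at this same place would move the number beyond the scatter. Changing the methyl ester to an amide is equally untested among these compounds.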